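The source may hold more compounds than are shown below. What is called first, only, known or untested is meant among the compounds shown, and "the series" means these compounds.

Of the compounds shown here, two have been measured so far in a physicochemical assay for solubility, in phosphate buffer (a higher number here means a more soluble compound, a lower number a less soluble compound), and neither gave a number. Compound 1 `Cc1cc(NC(=O)NCCCC[C@@H](Nc2cc(C)c(F)c(C)c2)C(=O)NO)ccc1F` returned > 5 ug/mL, which is a limit of the assay. Compound 2 `Cc1cc(N[C@H](CCCCNCc2cccc(F)c2)C(=O)NO)cc(C)c1F` returned > 5 ug/mL, which is also a limit. The record therefore consists of the limit of > 5 ug/mL in this assay, at which 2 of the 2 values shown sit, and compound 2 has no exact position on the scale. Going by the values given here, no two measured compounds differ in only one place, so no measured step is available as a guide.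

Compound 3 `Cc1cc(N[C@H](CCCCNCc2ccc(C(F)(F)F)cc2)C(=O)NO)cc(C)c1F` keeps the rest of compound 2 and carries 4-(trifluoromethyl)phenyl in place of 3-fluorophenyl on a saturated chain carbon bound to an amine nitrogen. The expectation for this change is loose, since it starts from compound 2 at > 5 ug/mL. In this assay, the expected change is a number no higher from compound 2 to compound 3 (the limit leaves the size open), an estimate of no step beyond the scatter in either direction. Compound 3 is estimated at 5 ug/mL, with an expected range from 2 ug/mL to 15 ug/mL.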

Compound 3, solubility: > 5 ug/mL
Compound 3 was reported as a limit; the forecaster's own chance of this, stated with the estimate: 50%; the middle value sits exactly at the limit.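

Going by these compounds alone, compound 3 gives > 5 ug/mL in this assay, which is a limit of the assay, and since compound 2 also sits at a limit, no step between compound 2 and compound 3 can be read. The compounds shown leave open where any of them lies on the solubility scale, and whether 4-(trifluoromethyl)phenyl in place of 3-fluorophenyl moves the value at all: the limit of > 5 ug/mL in this assay, at which 3 of the 3 values shown sit.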